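Benzyl Substituent Change Against a Cytotoxicity Ceiling

A few compounds are considered here, and "the series" means these few. Any claim that something is new, unique, unknown or untested is made for them only; others in the source may bear on it.

Measured compounds:
compound 1, `O=c1nc(N2CCN(NCc3ccc(OC(F)(F)F)cc3)CC2)sc2c([N+](=O)[O-])cc(C(F)(F)F)cc12`, gives > 64 ug/mL.
compound 2, `O=c1nc(N2CCN(NCc3ccc(C(F)(F)F)cc3)CC2)sc2c([N+](=O)[O-])cc(C(F)(F)F)cc12`, gives > 64 ug/mL.
compound 3, `O=c1nc(N2CCN(NCc3cc(F)cc(F)c3)CC2)sc2c([N+](=O)[O-])cc(C(F)(F)F)cc12`, gives > 64 ug/mL.

In an ADME assay on Vero cells (Chlorocebus sabaeus) for cytotoxicity, read by MTT assay, with a stated time of 72 h (on this read-out higher numbers stand for lower toxicity in this test and lower numbers for higher toxicity in this test), compound 3 gives > 64 ug/mL, which is a limit of the assay and not a number. In the same assay compound 1 gives > 64 ug/mL, again a limit. Compound 2 gives > 64 ug/mL, also a limit. The steps among them are therefore a step that the two limits leave unreadable from compound 1 to compound 2, a step that the two limits leave unreadable from compound 1 to compound 3 and a step that the two limits leave unreadable from compound 2 to compound 3; all three values sit at the limit of > 64 ug/mL in this assay, at which 3 of the 3 values shown sit.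

Compound 4, `O=c1nc(N2CCN(NCc3ccc(Br)cc3)CC2)sc2c([N+](=O)[O-])cc(C(F)(F)F)cc12`, differs from compound 3 by 4-bromophenyl in place of 3,5-difluorophenyl on a saturated chain carbon bound to an amine nitrogen. Going by the values given here, the steps that bear on this change are those into compound 3, from compound 1 and from compound 2, and both are unreadable because the limit of > 64 ug/mL in this assay, at which 3 of the 3 values shown sit, holds all of them. No step beyond the scatter is expected in this assay, and compound 4 is estimated at 80 ug/mL, between 40 ug/mL and 200 ug/mL, most likely reported again only as a limit; the expected step is a step that the limit leaves unreadable from compound 3 to compound 4.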

Compound 4, half-maximal cytotoxic concentration: > 64 ug/mL
Compound 4 ended at the assay's limit; the forecaster's own chance of this, stated with the estimate: 80%; the middle value is on the limit's open side.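

In this assay compound 4 gives > 64 ug/mL as a limit and not a number. Going by these compounds alone, no step among compound 1, compound 2, compound 3 and compound 4 can be read: the limit of > 64 ug/mL in this assay, at which 4 of the 4 values shown sit. The compounds shown leave open whether any benzyl substituent on the shared core changes the half-maximal cytotoxic concentration at all.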